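Selenocyanate chain in place of bromine on compound 2

A few compounds are considered here, and "the series" means these few. Any claim that something is new, unique, unknown or untested is made for them only; others in the source may bear on it.

Compound 1 `COc1ccc(N(C)c2ccnc(Cl)n2)cc1` gives 917 nM in a functional assay on HeLa cells (Homo sapiens) for antiproliferative activity, read by MTT assay, with a stated time of 48 h; on this read-out higher numbers stand for weaker inhibition and lower numbers for stronger inhibition. Compound 2 `COc1ccc(N(C)c2ccnc(Cl)n2)cc1OCCBr` gives 3310 nM; the step of a 3.6-fold higher number from compound 1 to compound 2 (0.56 log units; beyond the scatter) is the only one measured in the series. Compound 2 therefore stands highest of the two numbers, with compound 1 as its nearest neighbour. Compound 3 `COc1ccc(N(C)c2ccnc(Cl)n2)cc1OCCCCC[Se]C#N` differs from compound 2 by a group of 6 heavy atoms (4 carbon, 1 nitrogen, 1 selenium; no ring) in place of one bromine atom, on a saturated chain carbon, two bonds along the chain from an oxygen on an aromatic ring. Going by the values given here, no measured step bears directly on this exchange: the one known step concerns adding the chain to the core, not altering its terminus, and it raised the number by a modest amount. A change of this size at the chain end is expected to move the number little or somewhat further in the same direction, so the step of a 1.4-fold higher number from compound 2 to compound 3 (0.13 log units; within the scatter) is the expectation. Compound 3 is estimated at 4500 nM, within the range 1400 nM to 14000 nM.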

Compound 3, half-maximal inhibitory concentration: > 10000 nM
Compound 3: a limit, no number; the forecaster's own chance of this, stated with the estimate: 5%; at least 2.2-fold (0.34 log units) between middle value and limit.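

In this assay, the chain end proves sensitive to change: the selenocyanate chain in place of bromine gives an at least 3.0-fold higher number from compound 2 to compound 3 (0.48 log units; beyond the scatter). The result for compound 3 is a limit of the assay, not a number: the limit of > 10000 nM in this assay, at which 1 of the 3 values shown sits. Together with a 3.6-fold higher number from compound 1 to compound 2 (0.56 log units; beyond the scatter), this puts both measured steps in the direction of weaker inhibition, so the chain end on this series does not recover what adding the chain lost, and no compound shown goes against that direction.

From the compounds shown here alone, how far compound 3 lies past its limit stays open, and its step alters chain length and chain end at once, so the two cannot be separated. Also open, going by these compounds, is whether a longer chain ending in bromine, or an amine or a carboxylic acid at the chain end, would return the number towards that of compound 1 at 917 nM.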